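Pyrazoline amides: swapping an aroyl group for an aminoacetyl

A few compounds are considered here, and "the series" means these few. Any claim that something is new, unique, unknown or untested is made for them only; others in the source may bear on it.

The set begins with compound 1 `CC1=NN(C(=O)c2ccc([N+](=O)[O-])cc2)C(c2ccccc2O)C1` and compound 2 `CC1=NN(C(=O)CN2CCCC2)C(c2ccccc2O)C1`. Going by the values given here, in a functional assay on HepG2 cells (Homo sapiens) for cytotoxicity, read by MTT assay, with a stated time of 48 h (a higher number here means a weaker inhibitor, a lower number a stronger inhibitor), compound 1 gives 30100 nM, while compound 2 gives 5540 nM; these two are not a single-change pair, so the account says only that their two numbers differ. Compound 3 `Cc1ccc(C(=O)N2N=C(c3cc4ccccc4oc3=O)CC2c2ccccc2)cc1` is the third measured member. In this assay compound 3 gives 52300 nM, the highest of the three numbers; it lies within the usual scatter of compound 1 and well beyond it relative to compound 2.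

The piece follows the step to compound 4 `CC1CC(C)CN(CC(=O)N2N=C(c3cc4ccccc4oc3=O)CC2c2ccccc2)C1`, which is not yet measured. The change from compound 3 to compound 4 is (3,5-dimethylpiperidin-1-yl)methyl in place of 4-methylphenyl on a carbonyl carbon. Among the compounds with values here, compound 3 shares with compound 1 a carbonyl bearing an aromatic ring, and compound 2 is the only measured member carrying a carbonyl bearing an amine-containing methyl; that single compound sets the only hint available.

Compound 4 is expected in this assay to give a lower number than compound 3, by a 5.2-fold lower number from compound 3 to compound 4 (0.72 log units; beyond the scatter), because compound 2 reached 5540 nM with a related carbonyl substituent. The estimate for compound 4 is therefore 10000 nM, in a range from 3000 nM to 35000 nM.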

Compound 4, half-maximal inhibitory concentration: "not active" (no number reported)
Compound 4: no number reported, and the estimate cannot be compared.
By their numbers in this assay, from the lowest: compound 2; then compounds 1 and 3 (each within the scatter of the next).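

In this assay, going by these compounds alone, compound 4 is reported as "not active" with no number, so no step from compound 3 to compound 4 can be read. Nothing shown accounts for this result. The compounds shown leave open how (3,5-dimethylpiperidin-1-yl)methyl compares numerically with 4-methylphenyl on this carbonyl carbon.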